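Cytotoxicity notes on a methylimidazole amide series

The compounds below may be only part of what the source reports. "The series", "measured", "known", "first", "only" and "open" are said of these compounds alone.

compound 1 `Cn1c(-c2cccc(Cl)c2)cnc1NC(=O)c1ccc(F)cc1`: > 50000 nM
compound 2 `COc1ccc(-c2cnc(NC(=O)c3ccccc3F)n2C)cc1`: > 100000 nM
compound 3 `COc1ccc(-c2cn(C)c(NC(=O)c3ccc(F)cc3)n2)cc1`: > 50000 nM

Within the data shown here, in a toxicity assay on THP-1 cells (Homo sapiens) for inhibition (on this read-out higher numbers stand for lower toxicity in this test and lower numbers for higher toxicity in this test), no value so far is a number. Compound 2 sits at a limit of the assay, (the limit of > 100000 nM in this assay, at which 1 of the 3 values shown sits). Compound 1 sits at a different limit, (the limit of > 50000 nM in this assay, at which 2 of the 3 values shown sit), and compound 3 sits at the same limit. Nothing here separates the three.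

Compound 4 `COc1ccc(-c2cnc(NC(=O)c3cnc[nH]3)n2C)cc1` differs from compound 2 in one place:
1H-imidazol-5-yl in place of 2-fluorophenyl on a carbonyl carbon

Among the measured compounds shown here, no step between measured compounds is available. All three values shown are limits, and the expected step of an at least 1.2-fold lower number from compound 2 to compound 4 (0.09 log units; that floor lies within the scatter) is none beyond the scatter. Compound 4 is estimated at 80000 nM, with a range from 30000 nM to 200000 nM, and is expected most likely to return again as a limit rather than a number.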

Compound 4, half-maximal cytotoxic concentration: > 100000 nM
Compound 4 ended at the assay's limit; the forecaster's own chance of this, stated with the estimate: 85%; at least 1.2-fold (0.09 log units) between middle value and limit.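

Among these compounds, compound 4 gives > 100000 nM in this assay, which is a limit and not a number; compound 2 also stands at a limit, so no step between compound 2 and compound 4 can be read. The compounds shown leave open whether any of them has a numerical value in this assay.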